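Moving the chlorine around the ring on the triazole nitrogen

A few compounds are considered here, and "the series" means these few. Any claim that something is new, unique, unknown or untested is made for them only; others in the source may bear on it.

Compound 1, `Cc1cccc(-n2cc(-c3ccc(NS(=O)(=O)c4c[nH]c(=O)[nH]c4=O)cc3)nn2)c1`: in a functional assay on HepG2 cells (Homo sapiens) for antiproliferative activity, read by MTT assay, with a stated time of 24 h (a higher number here means a weaker inhibitor, a lower number a stronger inhibitor), only a limit is reported, > 20000 nM.
Compound 2, `O=c1[nH]cc(S(=O)(=O)Nc2ccc(-c3cn(-c4ccc(F)cc4)nn3)cc2)c(=O)[nH]1`: in this assay likewise only a limit, > 20000 nM.
Compound 3, `O=c1[nH]cc(S(=O)(=O)Nc2ccc(-c3cn(-c4ccccc4Cl)nn3)cc2)c(=O)[nH]1`: in this assay compound 3 gives 2230 nM.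

Among the measured compounds shown here, compound 3 thus holds the only real number among the three; the other two sit at the limit of > 20000 nM in this assay, at which 2 of the 3 values shown sit. The step from the 3-methylphenyl to the 4-fluorophenyl compound, a step that the two limits leave unreadable from compound 1 to compound 2, cannot be read. The two steps that end at compound 3 are readable: an at least 8.9-fold lower number from compound 1 to compound 3 (0.95 log units; beyond the scatter) and an at least 8.9-fold lower number from compound 2 to compound 3 (0.95 log units; beyond the scatter), both showing that the 2-chlorophenyl group goes with a clearly lower number than either other group on that nitrogen.

Compound 4, `O=c1[nH]cc(S(=O)(=O)Nc2ccc(-c3cn(-c4ccc(Cl)cc4)nn3)cc2)c(=O)[nH]1`, is not yet measured. Its change from compound 3 is 4-chlorophenyl in place of 2-chlorophenyl on an aromatic nitrogen. The 4-chlorophenyl group places the chlorine as the fluorine sits in compound 2, a compound that only reached the limit. The expectation is therefore a rise in the number, a 6.7-fold higher number from compound 3 to compound 4 (0.83 log units; beyond the scatter), rather than a further fall. Compound 4 is estimated at 15000 nM, within 4000 nM to 40000 nM, with a fair chance that only a limit is returned.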

Compound 4, half-maximal inhibitory concentration: 1980 nM
Beside the measured number, compound 4's estimate is 7.6-fold (0.88 log units) above it; the measured number lies below the stated range.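

Moving the chlorine around the ring makes no difference that can be told apart in this assay: the change gives a 1.1-fold lower number from compound 3 to compound 4 (0.05 log units; within the scatter), so for this pair the place of the chlorine does not separate the two compounds. The halogen matters more, since chloro in place of fluoro, with the ring otherwise the same, gives an at least 10-fold lower number from compound 2 to compound 4 (1.00 log units; beyond the scatter), and the 4-chlorophenyl group also stands clear of the 3-methylphenyl group, with an at least 10-fold lower number from compound 1 to compound 4 (1.00 log units; beyond the scatter). Both of these steps start from a limit rather than a number, so only their minimum size is known: the limit of > 20000 nM in this assay, at which 2 of the 4 values shown sit.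

Going by these compounds, what a bromine, an amine or a carboxylic acid on that phenyl ring would give remains open. The compounds shown also cannot tell why chloro and fluoro part so clearly.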